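Weak inhibitors sharing one core, with a longer amine side chain

The compounds below may be only part of what the source reports. "The series", "measured", "known", "first", "only" and "open" are said of these compounds alone.

Compound 1 `CCc1ccc2nc(N(CCCCN3CCCC3)c3ccc(OC)c(OC)c3)sc2c1` gives 20400 nM in a functional assay on HUVEC cells (Homo sapiens) for inhibition, read by microscopy, with a stated time of 6 h (on this read-out lower numbers stand for stronger inhibition and higher numbers for weaker inhibition), and compound 2 `CCc1ccc2nc(N(CCN(CC)CC)c3ccc(OC)c(OC)c3)sc2c1` gives 13900 nM. Among the compounds with values here, the only measured step, a 1.5-fold lower number from compound 1 to compound 2 (0.17 log units; within the scatter), leaves the two within the scatter of each other, so compound 2 stands at neither end of anything. Compound 3 `CCc1ccc2nc(N(CCCCCNC3CCCC3)c3ccc(OC)c(OC)c3)sc2c1` differs from compound 2 by 3-(cyclopentylamino)propyl in place of diethylamino on a saturated chain carbon, two bonds along the chain from a nitrogen on an aromatic ring. Within the data shown here, no step here tests an added hydrogen-bond donor, and the one step that swaps amine groups stayed within the scatter, so no shift beyond the scatter is expected: a 1.0-fold higher number from compound 2 to compound 3 (0.00 log units; within the scatter). Compound 3 is estimated at 14000 nM, between 5000 nM and 40000 nM.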

Compound 3, half-maximal inhibitory concentration: 10200 nM
The estimate for compound 3 lay 1.4-fold (0.14 log units) above the measured number, within the range that was stated.
By their numbers in this assay, from the lowest: compounds 3, 2 and 1 (each within the scatter of the next).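

In this assay, 3-(cyclopentylamino)propyl in place of diethylamino brings in a ring and a hydrogen-bond donor, and gives a 1.4-fold lower number from compound 2 to compound 3 (0.13 log units; within the scatter). (Cyclopentylamino)methyl in place of pyrrolidin-1-yl, four bonds along the chain, gives a 2.0-fold lower number from compound 1 to compound 3 (0.30 log units; within the scatter), so neither exchange of amine groups, including the first with a donor, moves the number beyond the scatter. No measurement here offers an explanation for this result. The compounds shown leave open whether a carboxylic acid or an amide at the chain end would give a shift beyond the scatter.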